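The source may report more compounds than this note shows. Statements on the series, on what has been measured and on what is new or still open speak of the compounds shown alone.

Compounds measured for solubility:
- Compound 1, `O=C(c1ccc(C(F)(F)F)cc1)N1CCC(NS(=O)(=O)c2cc(S(=O)(=O)c3ccccc3)ccc2C(F)(F)F)CC1`: 6300 nM
- Compound 2, `O=C(O)c1ccc(S(=O)(=O)N2CCC(NS(=O)(=O)c3cc(S(=O)(=O)c4ccccc4)ccc3C(F)(F)F)CC2)cc1`: 12500 nM

Going by the values given here, in a physicochemical assay for solubility (a lower number here means a less soluble compound, a higher number a more soluble compound), compound 1 gives 6300 nM, the lowest of the two numbers; compound 2 sits closest, and the only measured step, a 2.0-fold higher number from compound 1 to compound 2 (0.30 log units; within the scatter), lies within the scatter, so the two values cannot be ordered. Compound 3, `CC(C)(C)OC(=O)N1CC[C@@H](C(=O)N2CCC(NS(=O)(=O)c3cc(S(=O)(=O)c4ccccc4)ccc3C(F)(F)F)CC2)C1`, has not yet been measured in this assay. Its difference from compound 1 is 1-(tert-butoxycarbonyl)pyrrolidin-3-yl in place of 4-(trifluoromethyl)phenyl on a carbonyl carbon. Among the compounds with values here, no measured step concerns this change: the step from compound 1 to compound 2 alters the same ring nitrogen but with a different group, and it did not move the number beyond the scatter. With nothing more to go on, compound 3 is expected to stay near compound 1, with only a small step, a 1.4-fold higher number from compound 1 to compound 3 (0.15 log units; within the scatter), if any. The estimate for compound 3 in this assay is 9000 nM, with a range from 3000 nM to 30000 nM.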

Compound 3, solubility: 12500 nM
For compound 3 the middle estimate is 1.4-fold (0.14 log units) below the measured one, within the range that was stated.
By their numbers in this assay, from the lowest: compounds 1, 2 and 3 (each within the scatter of the next).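

In this assay, putting 1-(tert-butoxycarbonyl)pyrrolidin-3-yl in place of 4-(trifluoromethyl)phenyl on the carbonyl carbon gives a 2.0-fold higher number from compound 1 to compound 3 (0.30 log units; within the scatter). The earlier step replaced the whole acyl group on the ring nitrogen, whereas this one keeps the carbonyl and shows that a non-aromatic ring bearing hydrogen-bond acceptors can take the place of a fluorinated aromatic ring without a change that can be told from the scatter. Nothing available explains this result.

Going by these compounds, it remains open whether any group on this carbonyl carbon moves the number beyond the scatter, for example a pyrrolidine with a free amine in place of the tert-butoxycarbonyl-protected nitrogen. On these data alone, the effect of the opposite configuration at the defined stereocentre is equally open.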